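The source may hold more compounds than are shown below. What is called first, only, known or untested is meant among the compounds shown, and "the series" means these compounds.

Compound 1 `COc1ccc(C2CC(Nc3nc4ccc(C)cc4s3)=NN2C(C)=O)cc1O`: 73.9 umol/kg
Compound 2 `COc1ccc(C2CC(Nc3nc4ccc(Cl)cc4s3)=NN2C(C)=O)cc1O`: 127 umol/kg

Both numbers come from a functional assay on the whole organism (Hindlimb, strain albino) with Mus musculus as the target, in the maximal electroshock model, with a stated time of 0.5 h; on this read-out lower numbers stand for an effect already at smaller amounts and higher numbers for an effect only at larger amounts of compound. Compound 1 holds the lowest of the two numbers; the nearest is compound 2, and the step of a 1.7-fold higher number from compound 1 to compound 2 (0.24 log units; within the scatter) lies within the scatter, so no order between the two can be read. That single measured step, chloro in place of methyl on an aromatic carbon, alters an aromatic carbon elsewhere in the shared core, not the saturated ring carbon, and does not bear on the change to compound 3 `CC(=O)N1N=C(Nc2nc3ccc(C)cc3s2)CC1OC1=CC=C1`. That change is a group of 5 heavy atoms (4 carbon, 1 oxygen; one four-membered non-aromatic ring of carbon only) in place of a group of 9 heavy atoms (7 carbon, 2 oxygen; one six-membered aromatic ring of carbon only), on a saturated ring carbon: the 3-hydroxy-4-methoxyphenyl group leaves and a four-membered non-aromatic ring of carbon only enters on the saturated ring carbon. Going by the values given here, no measured pair tests this position, so the size and direction of the step are open, and the estimate is set near the measured numbers with a wide range. For compound 3 the expected step is a 2.0-fold higher number from compound 1 to compound 3 (0.31 log units; beyond the scatter). Compound 3 is expected at 150 umol/kg, between 50 umol/kg and 450 umol/kg.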

Compound 3, dose for half-maximal effect: 160 umol/kg
The estimate for compound 3 lay 1.1-fold (0.03 log units) below the measured number, and the stated range covers the measured number.
By their numbers in this assay, from the lowest: compounds 1, 2 and 3 (each within the scatter of the next, the first and the last beyond it).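

Going by these compounds alone, this is the first measured test of the saturated ring carbon: exchanging the 3-hydroxy-4-methoxyphenyl group for the smaller group with a four-membered non-aromatic carbon ring gives a 2.2-fold higher number from compound 1 to compound 3 (0.34 log units; beyond the scatter). The step is modest, so the six-membered aromatic ring, the hydroxy group and the methoxy group are not all needed on this carbon for an effect in the maximal electroshock model. No measured evidence accounts for the size of this step.

Within the data shown here, because the single pair changes the ring, the hydroxy group and the methoxy group together, the contribution of each remains unresolved. A plain phenyl, a 4-methoxyphenyl or a 3-hydroxyphenyl group on the same carbon would separate these parts, and a cyclobutyl or an aminomethyl group would extend the test beyond aromatic rings.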